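Adding a chloro group to compound 3

This account rests on a few compounds, and the source may have more. Where it says the series, first, only, none or still open, it means among the compounds named here.

compound 1 (`COc1ccccc1/C=C/C(=O)c1c(O)cc2occc2c1OC`): 10300 nM
compound 2 (`COc1c(C(=O)/C=C/c2ccc(Cl)cc2)c(O)c(Br)c2occc12`): 2130 nM
compound 3 (`C=CCc1c(O)c(C(=O)/C=C/c2ccccc2)c(OC)c2ccoc12`): 3070 nM

All three values come from a functional assay on MDA-MB-468 cells (Homo sapiens) for inhibition, with a stated time of 48 h (a higher number here means a weaker inhibitor of growth, a lower number a stronger inhibitor of growth), and can be compared directly. Compound 3 gives 3070 nM and compound 2 gives 2130 nM in the same test. These two lie within the normal scatter of repeated measurements, so they cannot be ranked. Compound 1 gives 10300 nM and is a weaker inhibitor of growth than compound 3, with a gap beyond the scatter.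

Compound 4 (`C=CCc1c(O)c(C(=O)/C=C/c2ccc(Cl)cc2)c(OC)c2ccoc12`) differs from compound 3 in one place: chloro in place of hydrogen on an aromatic carbon, para to a large group, which turns phenyl into 4-chlorophenyl (chloro in place of hydrogen on an aromatic carbon).

For the measured compounds named here, no two measured compounds differ in one place only, so this change has no direct precedent here. The nearest clue is compound 2, which also carries a 4-chlorophenyl and gives 2130 nM while other parts of its core differ. The expected move is a 1.5-fold lower number from compound 3 to compound 4 (0.16 log units; within the scatter) in this assay as a small shift toward a lower number, staying within the scatter. For compound 4 the estimated value is 2100 nM with an expected range from 900 nM to 4800 nM on this estimate.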

Compound 4, concentration for 50% growth inhibition: 2270 nM
Compound 4: middle estimate off by 1.1-fold (0.03 log units), on the low side; the measured number falls inside the stated range.
By their numbers in this assay, from the lowest: compounds 2, 4 and 3 (each within the scatter of the next); then compound 1.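

In this assay, for the compounds shown here, placing chloro on the aromatic carbon para to a large group, which turns phenyl into 4-chlorophenyl, gives a 1.4-fold lower number from compound 3 to compound 4 (0.13 log units; within the scatter) and so offers the first direct reading at this position: compound 3 and compound 4 cannot be ranked, and this single chloro has no effect that can be separated from ordinary assay noise. With 4-chlorophenyl held constant, allyl in place of bromo on an aromatic carbon gives a 1.1-fold higher number from compound 2 to compound 4 (0.03 log units; within the scatter) and so adds a second direct comparison, in which compound 2 and compound 4 cannot be ranked either, meaning that neither single change produces a measurable difference in this test. No measurement available here explains why these numbers stay so close.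

As far as these compounds go, it remains open whether an amine or a carboxylic acid in place of the chloro, on the same aromatic carbon, would shift the number beyond the scatter. From the compounds shown here alone, it is equally open whether a longer chain in place of allyl would produce a difference large enough to read in this assay on the shared core.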